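This account rests on a few compounds, and the source may have more. Where it says the series, first, only, none or still open, it means among the compounds named here.

Two close relatives have been tested so far in a functional assay on A549 cells (Homo sapiens) for inhibition, read by MTT assay, with a stated time of 72 h; on this read-out higher numbers stand for weaker inhibition and lower numbers for stronger inhibition. Compound 1 `Clc1ccc(-c2nnc(SCCCN3CCN(c4nc5ccccc5o4)CC3)o2)cc1` gives 127000 nM and compound 2 `O=[N+]([O-])c1ccc(-c2nnc(SCCCN3CCN(c4nc5ccccc5s4)CC3)o2)cc1` gives 96600 nM as its result. These two numbers lie within the usual scatter of each other, so the data cannot separate compound 2 from compound 1.

Compound 3 `Clc1ccc(-c2nnc(SCCCN3CCN(c4nc5ccccc5s4)CC3)o2)cc1` differs from compound 2 in one place: chloro in place of nitro on an aromatic carbon. Put simply, this is chloro in place of nitro on an aromatic carbon, which turns a 4-nitrophenyl into a 4-chlorophenyl. Going by the values given here, no measured pair shows this exchange on its own, so its size cannot be read directly from the data. The only clue is indirect: compound 1 also carries a 4-chlorophenyl, and compound 1 at 127000 nM stays within the scatter of compound 2 at 96600 nM as measured. On that basis, no shift beyond the scatter is expected in this assay, in either direction. The estimated change is small, a step of a 1.0-fold higher number from compound 2 to compound 3 (0.02 log units; within the scatter) as expected here. The estimated value for compound 3 is 100000 nM, with an expected range from 45000 nM to 200000 nM as its limits of confidence.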

Compound 3, half-maximal inhibitory concentration: 110000 nM
Compound 3: the middle estimate sits 1.1-fold (0.04 log units) below what was measured; low and high end bracket the measured number.
By their numbers in this assay, from the lowest: compounds 2, 3 and 1 (each within the scatter of the next).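

Compounds 1 and 2 differ in two places, so that pair could not show what either change does alone. In this assay, compound 3 now separates them: the change from 4-nitrophenyl to 4-chlorophenyl, para to a large group, gives a 1.1-fold higher number from compound 2 to compound 3 (0.06 log units; within the scatter) with the rest of the molecule held constant, so the data cannot tell these two groups apart at this position. The second change, 1,3-benzothiazol-2-yl in place of 1,3-benzoxazol-2-yl on an amine nitrogen in a ring, gives a 1.2-fold lower number from compound 1 to compound 3 (0.06 log units; within the scatter) and likewise cannot be told apart from no change, while no measurement here offers an explanation for either result.

Nitro and chloro are the only groups seen at the aromatic position, so it remains open whether an amine or a carboxylic acid there would move the number beyond the scatter. The compounds also leave open whether a longer chain between the sulfur and the ring nitrogen, or a methyl group on the benzothiazole, would separate any new compound from these three.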